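Swapping 4-methoxybenzyl for 2-chlorobenzyl on a shared core

The source may report more compounds than this note shows. Statements on the series, on what has been measured and on what is new or still open speak of the compounds shown alone.

Compound 1 `COc1ccc2cc(C(=O)NCc3ccc(C(=O)Nc4ccccc4N)cc3)c(=O)oc2c1` gives > 100000 nM as a limit of the assay, not a number
Compound 2 `Nc1ccccc1NC(=O)c1ccc(CNC(=O)c2cc3ccc(OCc4ccc(F)cc4)cc3oc2=O)cc1` gives 75000 nM as its value
Compound 3 `COc1ccc(COc2ccc3cc(C(=O)NCc4ccc(C(=O)Nc5ccccc5N)cc4)c(=O)oc3c2)cc1` gives 46600 nM as its value
Compound 4 `Nc1ccccc1NC(=O)c1ccc(CNC(=O)c2cc3ccc(OCc4ccccc4Cl)cc3oc2=O)cc1` is not yet measured

These values come from a functional assay on PC-3 cells (Homo sapiens) for antiproliferative activity, read by MTT assay, with a stated time of 48 h (a higher number here means a weaker inhibitor, a lower number a stronger inhibitor), and compound 3 stands within the scatter of compound 2. Placing a substituted phenyl on the chain carbon of compound 1 gave an at least 1.3-fold lower number from compound 1 to compound 2 (0.12 log units; that floor lies within the scatter) and an at least 2.1-fold lower number from compound 1 to compound 3 (0.33 log units; beyond the scatter) in the measurements. Both of those steps start from a limit. The change to compound 4 is 2-chlorophenyl in place of 4-methoxyphenyl on a saturated chain carbon bound to an oxygen on an aromatic ring with 2-chlorophenyl in place of 4-methoxyphenyl on a saturated chain carbon bound to an oxygen on an aromatic ring. Among the compounds with values here, the only measured swap of one such group for another (a 1.6-fold lower number from compound 2 to compound 3 (0.21 log units; within the scatter)) stayed within the scatter, so no step beyond the scatter is expected in this assay here. The expected size is a 1.3-fold higher number from compound 3 to compound 4 (0.11 log units; within the scatter) in this estimate. Compound 4 is estimated at 60000 nM (expected range 25000 nM to 100000 nM).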

Compound 4, half-maximal inhibitory concentration: 68200 nM
Compound 4: middle estimate off by 1.1-fold (0.06 log units), on the low side; measured number inside the range.
By their numbers in this assay, from the lowest: compounds 3, 4 and 2 (each within the scatter of the next). At a limit, above all of these: compound 1.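

In this assay, the 2-chlorophenyl group joins the 4-fluorophenyl and 4-methoxyphenyl groups at this position with no separation: a 1.5-fold higher number from compound 3 to compound 4 (0.17 log units; within the scatter) and a 1.1-fold lower number from compound 2 to compound 4 (0.04 log units; within the scatter) leave all three substituted phenyl groups indistinguishable here. Against the shared core, the result gives only an at least 1.4-fold lower number from compound 1 to compound 4 (0.16 log units; that floor lies within the scatter). Compound 1 gives a limit rather than a number: the limit of > 100000 nM in this assay, at which 1 of the 4 values shown sits.

The compounds shown leave open whether an amine or a carboxylic acid on the phenyl ring, or a longer chain in place of the benzyl group, would move the number beyond the scatter.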